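Chloro for trifluoromethyl on the hydrazone aryl ring

The source may hold more compounds than are shown below. What is called first, only, known or untested is meant among the compounds shown, and "the series" means these compounds.

Compounds measured so far:
- compound 1, `CC(=O)/C(=N\Nc1ccccc1)N(C)c1cccc(Cl)c1`: > 10000 nM
- compound 2, `CC(=O)/C(=N\Nc1ccccc1C(F)(F)F)N(C)c1cccc(Cl)c1`: > 10000 nM
- compound 3, `CC(=O)/C(=N\Nc1ccccc1Cl)Nc1cccc(Cl)c1`: 417 nM; 417 nM (2 entries)

In an assay on isolated protein for binding affinity to corticotropin-releasing factor receptor 1 (Homo sapiens) (a lower number here means a stronger inhibitor, a higher number a weaker inhibitor), compound 2 shows only a limit, > 10000 nM, and not a number. Compound 1 likewise shows only a limit in this assay, > 10000 nM. Compound 1 and compound 2 carry methyl on the aniline nitrogen, whereas compound 3 carries the hydrogen there; in this assay compound 3 gives 417 nM; 417 nM (2 entries). For the measured compounds named here, the one measured step, a step that the two limits leave unreadable from compound 1 to compound 2, cannot be read in size because of the limit of > 10000 nM in this assay, at which 2 of the 3 values shown sit.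

The change considered is chloro in place of trifluoromethyl on an aromatic carbon, giving compound 4, `CC(=O)/C(=N\Nc1ccccc1Cl)N(C)c1cccc(Cl)c1`. Going by the values given here, no measured step bears directly on a chloro entering for trifluoromethyl, and the step from compound 1 to compound 2 is unreadable, so no direction and no size can be drawn from it. Two of the three values in this assay sit at the limit, and compound 4 keeps the methyl on the aniline nitrogen that both compounds at the limit share. Compound 4 is therefore expected to be weak in this assay, with a step estimated as an at least 1.6-fold lower number from compound 2 to compound 4 (0.22 log units; that floor lies within the scatter). The estimate for compound 4 is 6000 nM, with a range of 1500 nM to 20000 nM.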

Compound 4, inhibition constant: > 10000 nM
Compound 4: a limit, no number (the forecaster's own chance of this, stated with the estimate: 55%); middle value at least 1.6-fold (0.22 log units) from the limit.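

In this assay compound 4 gives > 10000 nM, which is a limit and not a number. No new step can be read among compound 1, compound 2 and compound 4 because all three sit at that limit: the limit of > 10000 nM in this assay, at which 3 of the 4 values shown sit. The compounds shown leave open how chloro, trifluoromethyl and hydrogen on that aromatic carbon compare while methyl stays on the aniline nitrogen.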